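Hydroxy on the Aromatic Ring: Expected Inhibition of Compound 3

The source may report more compounds than this note shows. Statements on the series, on what has been measured and on what is new or still open speak of the compounds shown alone.

Measured compounds:
compound 1 `CN(C)C(=O)c1cc2cnc(Nc3ccc(C(=O)NCCCN=C=S)cc3)nc2n1C1CCCC1` 103%
compound 2 `CN(C)C(=O)c1cc2cnc(Nc3ccc(C(=O)NCCCCCCN=C=S)cc3)nc2n1C1CCCC1` 100%

In a functional assay on A549 cells (Homo sapiens) for inhibition, read by CCK-8 assay, with a stated time of 72 h, tested at 10 uM (a higher number here means a stronger effect of the compound at the concentration tested, a lower number a weaker effect), compound 1 gives 103% and compound 2 gives 100%. Compound 1 stands level with compound 2, since a number 3 percentage points lower from compound 1 to compound 2 (within the scatter). Compound 3 `CN(C)C(=O)c1cc2cnc(Nc3ccc(C(=O)NCCCN=C=S)cc3O)nc2n1C1CCCC1` differs from compound 1 by hydroxy in place of hydrogen on an aromatic carbon. Within the data shown here, the only measured step changes a chain, not the aromatic ring, so it bears on the new change merely by showing that this assay reads near complete inhibition for both. No step beyond the scatter is therefore expected in this assay, and the estimate for compound 3 is 98% (range 82% to 106%), a step of a number 5 percentage points lower from compound 1 to compound 3 (within the scatter).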

Compound 3, a percentage reported as inhibition, at one concentration (the size of the read-out at that concentration, not a potency): 73%
Compound 3: the middle estimate sits 25 percentage points above what was measured, outside the stated range (below it).
By their numbers in this assay, from the lowest: compound 3; then compounds 2 and 1 (each within the scatter of the next).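

Hydroxy in place of hydrogen on this aromatic carbon, ortho to a large group, gives in this assay a number 30 percentage points lower from compound 1 to compound 3 (beyond the scatter) and so has a real effect on the read-out. Among these compounds, the earlier compounds changed only the chain, so this is the first sign that this ring position responds to a small change. Nothing available explains the drop.

Going by these compounds, whether a methoxy group, a fluorine atom or an amine on the same carbon would act like hydroxy remains open. So does whether hydroxy would have the same effect with the longer chain of compound 2.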